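A few compounds are considered here, and "the series" means these few. Any claim that something is new, unique, unknown or untested is made for them only; others in the source may bear on it.

Compound 1, `Cc1ccccc1S(=O)(=O)N1CCN(c2ccc(C(=O)NCc3cccs3)nn2)CC1`: in an ADME assay on microsomes from liver (Mus musculus), read by LC-MS, using NADPH, tested at 10 uM (a lower number here means that the liver removes a smaller share, a higher number that the liver removes a larger share of the compound in one pass), compound 1 gives 0.97.
Compound 2, `Cc1ccccc1S(=O)(=O)N1CCN(c2cnc(C(=O)NCc3ccc(F)cc3)cn2)CC1`: in this assay compound 2 gives 0.95.
Compound 3, `O=C(NCc1ccccc1)c1ccc(N2CCN(S(=O)(=O)c3cccc(Cl)c3Cl)CC2)nn1`: in this assay compound 3 gives 0.81.

Among these three, compound 3 stands lowest; compound 2 sits a step higher that lies beyond the scatter, and compound 1 further still, also beyond the scatter. Compound 4, `O=C(NCc1ccccc1)c1ccc(N2CCN(S(=O)(=O)c3ccccc3Cl)CC2)nn1`, has not yet been measured in this assay. It differs from compound 3 in one place: hydrogen in place of chloro on an aromatic carbon. Going by the values given here, no measured pair shows this change, so the size of the step cannot be read from the numbers at hand. All three measured values sit in the upper part of the scale, which gives no ground to expect a large move in either direction. Compound 4 is therefore expected to give 0.86, with a range from 0.72 to 0.97. The step this estimate means is a number 0.050 higher from compound 3 to compound 4 (within the scatter), expected to lie within the scatter or to lean slightly upward.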

Compound 4, hepatic extraction ratio: 0.97
Compound 4: the middle estimate sits 0.11 below what was measured; low and high end bracket the measured number.
By their numbers in this assay, from the lowest: compound 3; then compounds 2, 1 and 4 (each within the scatter of the next).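

Going from (2,3-dichlorophenyl)sulfonyl to (2-chlorophenyl)sulfonyl gives a number 0.16 higher from compound 3 to compound 4 (beyond the scatter) in this assay. This single pair shows that this aromatic carbon, meta to a large group and ortho to a chloro group, is not neutral for this read-out: the number depends on whether it carries chloro or hydrogen. The compounds give no measurement that explains this step.

From the compounds shown here alone, whether a fluoro, methoxy or nitrile group on this carbon would behave like chloro or like hydrogen stays open. So does whether the step would recur with the thiophene amide of compound 1.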